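Series notes: aryl substitution with the propanoic acid side chain

The source may hold more compounds than are shown below. What is called first, only, known or untested is meant among the compounds shown, and "the series" means these compounds.

Measured so far in an assay on CHO cells for agonist activity at Free fatty acid receptor 1 (Homo sapiens), read by FLIPR; on this read-out higher numbers stand for an effect only at larger amounts of compound and lower numbers for an effect already at smaller amounts:
compound 1 `Cc1nc(-c2ccccc2)sc1COc1ccc(S(=O)(=O)CC(=O)O)cc1`, 370 nM
compound 2 `Cc1nc(-c2ccccc2)sc1COc1ccc(CCC(=O)O)cc1`, 590 nM

In this assay compound 1 gives 370 nM and compound 2 gives 590 nM. Compound 2 stands at the larger of the two numbers, with compound 1 the nearest point, but the step of a 1.6-fold higher number from compound 1 to compound 2 (0.20 log units; within the scatter) is within the scatter, so the two compounds are not separated on this read-out.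

Compound 3 `Cc1nc(-c2ccc(C(F)(F)F)cc2)sc1COc1ccc(CCC(=O)O)cc1` differs from compound 2 by trifluoromethyl in place of hydrogen on an aromatic carbon. Among the measured compounds shown here, no measured step bears on this position: the only step available, a 1.6-fold higher number from compound 1 to compound 2 (0.20 log units; within the scatter), concerns the acid side chain, not the aryl on the shared core. There is therefore no basis in the measured compounds for a directional expectation. The step from compound 2 to compound 3 is expected to be a 1.5-fold lower number from compound 2 to compound 3 (0.17 log units; within the scatter), not beyond the scatter. Compound 3 is estimated at 400 nM, with a range of 130 nM to 1300 nM.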

Compound 3, half-maximal effective concentration: 325 nM
Beside the measured number, compound 3's estimate is 1.2-fold (0.09 log units) above it, within the range that was stated.
By their numbers in this assay, from the lowest: compounds 3, 1 and 2 (each within the scatter of the next).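

Trifluoromethyl on an aromatic carbon of the six-membered ring of carbon only, para to a large group, is the first change on the aryl of the shared core rather than on the acid side chain. In this assay the step of a 1.8-fold lower number from compound 2 to compound 3 (0.26 log units; within the scatter) does not separate the two compounds, so this place carries trifluoromethyl in place of hydrogen with no step beyond the scatter. No evidence at hand accounts for this result.

From the compounds shown here alone, whether another group at this place, such as a nitrile, a methoxy group or a chlorine atom, would give a step beyond the scatter remains open. Also open, going by these compounds, is whether trifluoromethyl would give a similar step on the (carboxymethyl)sulfonyl side chain of compound 1.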